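The source may hold more compounds than are shown below. What is called first, only, known or untested is meant among the compounds shown, and "the series" means these compounds.

Measured so far in an ADME assay on RAW264.7 cells (Mus musculus) for cytotoxicity, read by MTT assay, with a stated time of 24 h; on this read-out lower numbers stand for higher toxicity in this test and higher numbers for lower toxicity in this test:
Compound 1 `CC/C=C\C[C@H]1C(=O)C=C[C@H]1CC(=O)OCCCCC` gives 37 uM
Compound 2 `CC/C=C\C[C@H]1C(=O)C=C[C@H]1CC(=O)Oc1ccc(O)cc1` gives 49 uM
Compound 3 `CC/C=C\C[C@H]1C(=O)C=C[C@H]1CC(=O)OC(C)CC` gives 53 uM

Compound 3 at 53 uM lies within the scatter of both other compounds and holds no clear rank among them. Compound 4 `CC/C=C\C[C@H]1C(=O)C=C[C@H]1CC(=O)OC(C)COC` differs from it by a single change (methoxy in place of methyl on a saturated chain carbon, two bonds along the chain from an oxygen next to a carbonyl group), with methoxy in place of methyl on a saturated chain carbon, two bonds along the chain from an oxygen next to a carbonyl group. The measured swaps of the group on that oxygen were all small (a 1.4-fold higher number from compound 1 to compound 3 (0.16 log units; within the scatter) and a 1.1-fold higher number from compound 2 to compound 3 (0.03 log units; within the scatter) and a 1.3-fold higher number from compound 1 to compound 2 (0.12 log units; within the scatter)), though none of them tests methoxy itself. In this assay no step beyond the scatter is therefore expected. The expected step is a 1.1-fold lower number from compound 3 to compound 4 (0.03 log units; within the scatter) and it stays within the scatter. The estimate for compound 4 is 50 uM (expected range 28 uM to 90 uM).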

Compound 4, half-maximal toxic concentration: 161 uM
The estimate for compound 4 lay 3.2-fold (0.51 log units) below the measured number; measured number above the stated range.
By their numbers in this assay, from the lowest: compounds 1, 2 and 3 (each within the scatter of the next); then compound 4.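

In this assay, methoxy in place of methyl on a saturated chain carbon, two bonds along the chain from an oxygen next to a carbonyl group, gives the first step beyond the scatter among these esters (a 3.0-fold higher number from compound 3 to compound 4 (0.48 log units; beyond the scatter)). The 1-(methoxymethyl)ethyl group also stands clear of 4-hydroxyphenyl (a 3.3-fold higher number from compound 2 to compound 4 (0.52 log units; beyond the scatter)) and of pentyl (a 4.4-fold higher number from compound 1 to compound 4 (0.64 log units; beyond the scatter)), whereas the swaps among those earlier groups all stayed within the scatter. No evidence at hand accounts for this step. The compounds shown leave open how an ethoxy, an amine or a carboxylic acid on that same chain carbon would read. They also leave open whether a longer chain beyond the methoxy oxygen would keep the higher number.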